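A few compounds are considered here, and "the series" means these few. Any claim that something is new, unique, unknown or untested is made for them only; others in the source may bear on it.

The study concerns three measured analogues on one shared core and a fourth not yet tested. Compound 1 `O=C(/C=C/c1ccccc1)c1ccc[nH]1` is the parent; in a functional assay on HeLa cells (Homo sapiens) for inhibition, read by MTT assay, with a stated time of 48 h (on this read-out higher numbers stand for weaker inhibition and lower numbers for stronger inhibition), compound 1 gives only a limit, > 100000 nM, and no number. Compound 2 `O=C(/C=C/c1cccc([N+](=O)[O-])c1)c1ccc[nH]1` bears a nitro group, and in this assay compound 2 gives 32000 nM. Among the compounds with values here, compound 3 `COc1cccc(/C=C/C(=O)c2ccc[nH]2)c1` bears a methoxy group instead, and in this assay compound 3 gives 30000 nM, so compound 2 stands alongside compound 3, the only other number, within the scatter of it. The step of an at least 3.1-fold lower number from compound 1 to compound 2 (0.49 log units; beyond the scatter) and the step of an at least 3.3-fold lower number from compound 1 to compound 3 (0.52 log units; beyond the scatter) are both beyond the scatter, while the step of a 1.1-fold lower number from compound 2 to compound 3 (0.03 log units; within the scatter) is not; since compound 1 sits at the limit of > 100000 nM in this assay, at which 1 of the 3 values shown sits, the first two steps are only lower bounds.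

Compound 4 `O=C(/C=C/c1cc([N+](=O)[O-])ccc1Cl)c1ccc[nH]1` differs from compound 2 by chloro in place of hydrogen on an aromatic carbon. Within the data shown here, no measured step adds a chloro group, so the nearest guides are the substitutions on the same ring behind the steps of an at least 3.1-fold lower number from compound 1 to compound 2 (0.49 log units; beyond the scatter) and an at least 3.3-fold lower number from compound 1 to compound 3 (0.52 log units; beyond the scatter), each at least modest, and the swap a 1.1-fold lower number from compound 2 to compound 3 (0.03 log units; within the scatter), which stayed within the scatter. On that basis only a small move toward a lower number is expected, with the step of a 1.6-fold lower number from compound 2 to compound 4 (0.20 log units; within the scatter) as the estimate. Compound 4 is therefore expected to give 20000 nM in this assay, with a likely range from 6000 nM to 60000 nM.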

Compound 4, half-maximal inhibitory concentration: 68000 nM
Compound 4: middle estimate off by 3.4-fold (0.53 log units), on the low side, outside the stated range (above it).
By their numbers in this assay, from the lowest: compounds 3 and 2 (each within the scatter of the next); then compound 4. At a limit, above all of these: compound 1.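

In this assay, chloro in place of hydrogen on the ring that already carries the nitro group gives a 2.1-fold higher number from compound 2 to compound 4 (0.33 log units; beyond the scatter), a modest step beyond the scatter, so substitution at this position, ortho to a group of 9 heavy atoms and para to a nitro group, does change the read-out. The earlier steps from compound 1, nitro or methoxy in place of hydrogen, both went toward lower numbers, whereas this is the first step shown that goes toward a higher number and so toward weaker inhibition, and the first that adds a group to a ring already bearing one; a new group on this ring therefore does not always lower the number. Nothing shown here gives a reason for the direction of this step.

The compounds shown leave open whether the higher number belongs to chloro as such or to this place on the ring, and whether the same step would hold on compound 3 with its methoxy group. They also leave open how a fluoro group, a methyl group or an amine at this position would read in this assay.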